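A few compounds are considered here, and "the series" means these few. Any claim that something is new, unique, unknown or untested is made for them only; others in the source may bear on it.

Working notes on the sulfonamide series.

Two compounds are measured in an assay on MDA-MB-231 cells for binding affinity to C-X-C chemokine receptor type 4 (Homo sapiens), read by fluorescence and microscopy, with stated times of 10 min and 30 min; on this read-out lower numbers stand for an effect already at smaller amounts and higher numbers for an effect only at larger amounts of compound. Compound 1 `O=C(NCc1ccc(CNS(=O)(=O)c2cccnc2)cc1)c1ccc(F)cc1` gives 1000 nM. Compound 2 `O=C(NCc1ccc(CNS(=O)(=O)c2ccccc2F)cc1)c1ccc(F)cc1` gives 10 nM. Among the measured compounds shown here, the single step between them, a 100-fold lower number from compound 1 to compound 2 (2.00 log units; beyond the scatter), shows that the aryl group on the sulfonyl sulfur carries much of the read-out: compound 2 stands lowest of the two numbers, with compound 1 as its only neighbour at a far higher value.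

Compound 3 `Cc1cccc(S(=O)(=O)NCc2ccc(CNC(=O)c3ccc(F)cc3)cc2)c1` is the next member. Its difference from compound 2 is 3-methylphenyl in place of 2-fluorophenyl on a sulfonyl sulfur. For the measured compounds named here, no measured step addresses this exchange: the only step known changes pyridin-3-yl to 2-fluorophenyl, and it speaks to the sensitivity of this position, not to the direction of a fluorine-to-methyl swap on a carbon-only ring. The one six-membered aromatic ring of carbon only is kept, so the large gap seen for compound 1 need not recur. Expected for compound 3, with wide uncertainty in either direction, is a number in this assay near 40 nM, with a range from 5 nM to 400 nM, meaning an estimated step of a 4.0-fold higher number from compound 2 to compound 3 (0.60 log units; beyond the scatter).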

Compound 3, effective concentration (reported as EC, without a stated level of effect): 1 nM
Estimate against measurement, compound 3: 40-fold (1.60 log units) above, and the stated range ends above it.
By their numbers in this assay, from the lowest: compound 3; then compound 2; then compound 1.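

Both 2-fluorophenyl and 3-methylphenyl carry one six-membered aromatic ring of carbon only and no hydrogen-bond donors or acceptors, yet a 10-fold lower number from compound 2 to compound 3 (1.00 log units; beyond the scatter) stands in this assay as a step beyond the scatter, so this position on the sulfonyl sulfur still discriminates once pyridin-3-yl is out of the comparison. The earlier step could be read as a contrast between pyridin-3-yl and a carbon-only ring, whereas the new one shows that exchanges among carbon-only rings also move the number, with 3-methylphenyl rather than 2-fluorophenyl now giving the lowest of the three. The span at this position widens to a 1000-fold lower number from compound 1 to compound 3 (3.00 log units; beyond the scatter) and so exceeds the step first seen there, while nothing available gives a reason for either new step.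

The compounds shown do not separate the contribution of the methyl group from that of its place on the ring, and they include no unsubstituted phenyl as a common reference for the methyl and fluorine groups. Going by these compounds, it also remains open whether the low number would hold with a larger or charged group on the ring, such as an amine, a carboxylic acid or a longer alkyl chain in place of the methyl group.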